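From chloro to dimethylamino on a shared core

The compounds below may be only part of what the source reports. "The series", "measured", "known", "first", "only" and "open" are said of these compounds alone.

Measured so far in a functional assay on L1210 cells (Mus musculus) for inhibition (a lower number here means a stronger inhibitor, a higher number a weaker inhibitor), with these results:
Compound 1 (`C=C1[C@H](n2ccc(=O)[nH]c2=O)O[C@H](CO)[C@H]1O`): > 500000 nM
Compound 2 (`C=C1[C@@H](O)[C@H](n2cnc3c(O)ncnc32)O[C@@H]1CO`): > 200000 nM
Compound 3 (`C=C1[C@H](n2cnc3c(Cl)nc(N)nc32)O[C@H](CO)[C@H]1O`): 10000 nM

For the measured compounds named here, compound 3 gives 10000 nM as its result, and this is the only true number among the three. For compound 1 the entry > 500000 nM is a limit of the assay and not a number. For compound 2 the entry > 200000 nM is also a limit of the assay.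

Compound 4 (`C=C1[C@H](n2cnc3c(N(C)C)nc(N)nc32)O[C@H](CO)[C@H]1O`) differs from compound 3 in one place, with dimethylamino in place of chloro on an aromatic carbon. Going by the values given here, no two measured compounds differ in only one place, so no measured step shows how large this change might be in this assay on its own. Among the compounds with values here, compound 3 (10000 nM) is the only measured compound carrying a chloro, and that is the group that leaves here. Weaker inhibition, beyond the usual scatter, therefore seems the more likely outcome, although this rests on very little data. The expected change is a 6.0-fold higher number from compound 3 to compound 4 (0.78 log units; beyond the scatter) in the direction of weaker inhibition. For compound 4 the estimated value is 60000 nM with an expected range from 15000 nM to 250000 nM for the measurement.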

Compound 4, half-maximal inhibitory concentration: 454000 nM
Beside the measured number, compound 4's estimate is 7.6-fold (0.88 log units) below it, outside the stated range (above it).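

In this assay, for the compounds shown here, replacing chloro with dimethylamino on the aromatic carbon next to the ring nitrogen gives a 45-fold higher number from compound 3 to compound 4 (1.66 log units; beyond the scatter), the first measured change at a single place on this core. It shows that this position is not indifferent to what sits on it: with the same core and the same amino group on the ring, the dimethylamino group, with 3 heavy atoms where chloro has 1, comes with far weaker inhibition than chloro. Nothing measured here explains why this one change matters so much.

With only chloro and dimethylamino shown at this position, it remains open whether a simple amine, a methylamino group or a methoxy group on the same carbon would stay close to compound 3 or fall close to compound 4. On these data alone, it is also open whether chloro itself is special, or whether another halogen such as fluorine or bromine, or plain hydrogen, would serve as well.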